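Isoquinolinyl ether in a series of aspartyl ketones

The source may hold more compounds than are shown below. What is called first, only, known or untested is meant among the compounds shown, and "the series" means these compounds.

Compound 1 `CC(C)[C@H](NC(=O)COc1cccc2ccccc12)C(=O)N[C@@H](CC(=O)O)C(=O)CSc1nc(-c2ccccc2)c(-c2ccccc2)[nH]1` and compound 2 `CC(C)[C@H](NC(=O)COc1cccc2ccccc12)C(=O)N[C@@H](CC(=O)O)C(=O)COc1nc2ccccc2[nH]1` share a core and differ in the ether on the carbon next to the ketone. In a functional assay on Jurkat cells (Homo sapiens) for inhibition (a lower number here means a stronger inhibitor, a higher number a weaker inhibitor), compound 1 reaches only the limit > 200000 nM. In this assay compound 2 likewise reaches only the limit > 200000 nM. Both values sit at the limit of > 200000 nM in this assay, at which 2 of the 2 values shown sit, so compound 2 stands nowhere above that limit. Compound 3 `CC(C)[C@H](NC(=O)COc1cccc2ccccc12)C(=O)N[C@@H](CC(=O)O)C(=O)COc1nccc2ccccc12` carries isoquinolin-1-yl in place of 1H-benzimidazol-2-yl on an oxygen on a saturated carbon. No change beyond the scatter is expected from compound 2 to compound 3, a number no higher from compound 2 to compound 3 (the limit leaves the size open), and compound 3 is estimated at 200000 nM, between 60000 nM and 600000 nM, most likely again as a limit.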

Compound 3, half-maximal inhibitory concentration: 106000 nM
For compound 3 the middle estimate is 1.9-fold (0.28 log units) above the measured one; measured number inside the range.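

In this assay, among these compounds, compound 3 gives 106000 nM, the first value at this position that is a number and not a limit, so exchanging 1H-benzimidazol-2-yl for isoquinolin-1-yl on the oxygen brings the series into measurable range. The change reads as an at least 1.8-fold lower number from compound 2 to compound 3 (0.27 log units; that floor lies within the scatter). Its true size stays open, since compound 2 gives only a limit: the limit of > 200000 nM in this assay, at which 2 of the 3 values shown sit.

Open, from the compounds shown here alone, is whether pyridin-2-yl on the same oxygen, or an amine or carboxylic acid on the isoquinolin-1-yl group, would move the number further.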